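Methyl on the cyclobutane ring carbon: compound 2 to compound 4

This account rests on a few compounds, and the source may have more. Where it says the series, first, only, none or still open, it means among the compounds named here.

Measured so far:
compound 1, `C[C@]1(O)C[C@](c2cccc(OC(F)(F)F)c2)([C@H](O)c2ccccn2)C1`, 1310 nM
compound 2, `O[C@H](c1ccccn1)[C@]1(c2cccc(OC(F)(F)F)c2)C[C@@H](O)C1`, 80 nM
compound 3, `O[C@H](c1ccccn1)[C@]1(c2cccc(C(F)(F)F)c2)C[C@@H](O)C1`, 210 nM

In an assay on HEK293 cells for antagonist activity at transient receptor potential cation channel subfamily V member 3 (Homo sapiens), read by FLIPR and calcium flux (a higher number here means a weaker inhibitor, a lower number a stronger inhibitor), compound 2 gives the lowest of the three numbers; compound 3 sits nearest, compound 1 furthest. Among the measured compounds shown here, the one measured step, a 2.6-fold higher number from compound 2 to compound 3 (0.42 log units; beyond the scatter), concerns the group on the aromatic ring and does not touch the ring carbon changed here.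

Compound 4, `C[C@]1(O)C[C@@](c2cccc(OC(F)(F)F)c2)([C@H](O)c2ccccn2)C1`, differs from compound 2 by methyl in place of hydrogen on a saturated ring carbon. For the measured compounds named here, no measured step covers exactly this change. Going by the values given here, compound 1 also carries a methyl and a hydroxy on that ring carbon, with its own configuration, and gives 1310 nM in this assay; no computed step from compound 2 to compound 1 is available, so its value serves only as a reference point. The expectation for compound 4 is therefore a weaker inhibitor than compound 2, with the step of a 4.4-fold higher number from compound 2 to compound 4 (0.64 log units; beyond the scatter) expected but uncertain in size. Compound 4 is estimated at 350 nM, within 90 nM to 1400 nM.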

Compound 4, antagonist equilibrium constant: 280 nM
Estimate against measurement, compound 4: 1.3-fold (0.10 log units) above; low and high end bracket the measured number.
By their numbers in this assay, from the lowest: compound 2; then compounds 3 and 4 (each within the scatter of the next); then compound 1.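

In this assay, methyl in place of hydrogen on this saturated ring carbon weakens inhibition only modestly: a 3.5-fold higher number from compound 2 to compound 4 (0.54 log units; beyond the scatter). The ring carbon therefore accepts a methyl alongside its hydroxy, with compound 4 retaining measurable activity. The configuration matters at least as much as the added methyl, since the gap between the two methyl compounds, a 4.7-fold lower number from compound 1 to compound 4 (0.67 log units; beyond the scatter), goes with stereochemistry alone, and the basis for that reading is: the fact that compounds 1 and 4 differ only in the configuration as drawn

Two saturated ring carbons differ in their drawn configuration between compound 1 and compound 4, and the compounds shown do not separate their contributions. Also open, going by these compounds, is how this assay would read an ethyl group on this ring carbon, or an amine in place of its hydroxy.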